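The compounds below may be only part of what the source reports. "The series", "measured", "known", "first", "only" and "open" are said of these compounds alone.

In a functional assay on the whole organism (strain Albino) with Mus musculus as the target, with a stated time of 4 h (a lower number here means that less compound is needed, a higher number that more compound is needed for the effect), three compounds have been measured:

Compound 1, `COc1ccc(-c2cc(-c3ccc(F)cc3)nc(NC(=O)N/N=C\c3ccccc3[N+](=O)[O-])n2)c(OC)c1`, gives 300 mg/kg.
Compound 2, `COc1ccc(/C(C)=N\NC(=O)Nc2nc(-c3ccc(F)cc3)cc(-c3ccc([N+](=O)[O-])cc3)n2)cc1`, gives 300 mg/kg.
Compound 3, `C/C(=N/NC(=O)Nc1nc(-c2ccc(C)cc2)cc(-c2ccc(F)cc2)n1)c1ccc([N+](=O)[O-])cc1`, gives 300 mg/kg.

All three share the same acylated hydrazone core, and in this assay compound 3 stands level with compound 1 and compound 2 at the digits recorded; the three values show no difference beyond the scatter, and no ordering among them can be read off.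

Compound 4, `C/C(=N/NC(=O)Nc1nc(-c2ccc(C)cc2)cc(-c2ccc(F)cc2)n1)c1ccc(Cl)cc1`, has not yet been measured. It is reached from compound 3 by a single alteration: chloro in place of nitro on an aromatic carbon. The hydrazone arm is otherwise unchanged, and the core is untouched.

Among the compounds with values here, no pair of measured compounds differs in only one place, so there is no measured step from which the size of this change could be gauged. What is known is that three compounds with quite different peripheral substituents all settle at the same value in this assay. On that basis the expected step from compound 3 to compound 4 is no change at the digits printed from compound 3 to compound 4 (within the scatter), that is, no change beyond the scatter in either direction. Compound 4 is therefore expected to give about 300 mg/kg, with a plausible range from 150 mg/kg to 600 mg/kg.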

Compound 4, dose for half-maximal effect: 300 mg/kg
Compound 4: the middle estimate sits on the measured number at the digits printed; low and high end bracket the measured number.
By their numbers in this assay, from the lowest: compounds 1, 2, 3 and 4 (each within the scatter of the next).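

In this assay, the step from nitro to chloro gives the first single-place comparison among these compounds: no change at the digits printed from compound 3 to compound 4 (within the scatter). It shows that, on this aromatic carbon para to a large group, the 4-nitrophenyl can give way to the 4-chlorophenyl, with three heavy atoms and two hydrogen-bond acceptors replaced by one heavy atom and no acceptor, without a shift beyond the scatter, something compounds 1, 2 and 3 could not show because no two of them differ in only one place. Nothing available bears on why the value holds across this change.

Within the data shown here, whether the same holds for an amine, a carboxylic acid or a longer alkyl chain at this position remains open, since nitro and chloro are the only two groups compared here with everything else held fixed. Also open, going by these compounds, is whether any single change to the hydrazone arm or to the shared core would move the number in this assay, as this one step speaks only for this position.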